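The source may hold more compounds than are shown below. What is called first, only, known or untested is meant among the compounds shown, and "the series" means these compounds.

Measured so far in an in vitro assay on HEK385-7 cells for displacement of a labelled ligand from prostaglandin D2 receptor 2 (Homo sapiens); on this read-out higher numbers stand for weaker inhibition and lower numbers for stronger inhibition:

compound 1 `O=C(O)Cc1sc(C(c2ccc(F)cc2)c2ccc(F)cc2)nc1-c1cc(F)nc(F)c1`: 5.4 nM
compound 2 `Cc1cc(-c2nc(C(c3ccc(F)cc3)c3ccc(F)cc3)sc2CC(=O)O)ccn1`: 3.1 nM

Compound 2 is one of two numbers in this assay and is not separated from compound 1: the step of a 1.7-fold lower number from compound 1 to compound 2 (0.24 log units; within the scatter) is within the scatter, so the two values are read as equivalent.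

Compound 3 `O=C(O)Cc1sc(C(c2ccc(F)cc2)c2ccc(F)cc2)nc1-c1ccnc(N2CCC2)c1` differs from compound 2 by azetidin-1-yl in place of methyl on an aromatic carbon. Going by the values given here, the only measured step that bears on this position is the step from compound 1 to compound 2, which also reworked the groups on the six-membered aromatic ring with one nitrogen and gave a 1.7-fold lower number from compound 1 to compound 2 (0.24 log units; within the scatter), within the scatter. Among the compounds with values here, no measured step exchanges methyl for a ring at this place, so the expectation can only be carried over from that one step. Compound 3 is therefore expected to show no change beyond the scatter, a 1.1-fold higher number from compound 2 to compound 3 (0.05 log units; within the scatter). The estimate for compound 3 in this assay is 3.5 nM, in a range from 1.2 nM to 10 nM.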

Compound 3, half-maximal inhibitory concentration: 660 nM
Beside the measured number, compound 3's estimate is 190-fold (2.28 log units) below it, outside the stated range (above it).
By their numbers in this assay, from the lowest: compounds 2 and 1 (each within the scatter of the next); then compound 3.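

In this assay this position, on an aromatic carbon next to the ring nitrogen, does not accept every group: azetidin-1-yl in place of methyl gives a 210-fold higher number from compound 2 to compound 3 (2.33 log units; beyond the scatter) and so separates compound 3 clearly from the earlier pair, which had stayed within the scatter of each other. The comparison with the difluorinated compound reads the same way, with a 120-fold higher number from compound 1 to compound 3 (2.09 log units; beyond the scatter) on going to 2-(azetidin-1-yl)pyridin-4-yl, so the loss does not depend on which earlier compound serves as the reference. No supporting data are at hand to explain this loss.

Open, from the compounds shown here alone, is whether the loss goes with the azetidine ring itself or with any amine at this place; dimethylamino, an open-chain amine, and pyrrolidin-1-yl would help separate the two. Also open, going by these compounds, is whether a carbon-only group such as ethyl keeps the number close to that of compound 2.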